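Fluoro position shift on the stilbene-type phenyl ring

The compounds below may be only part of what the source reports. "The series", "measured", "known", "first", "only" and "open" are said of these compounds alone.

Measured compounds:
- compound 1, `CN(C)CCCCOc1ccccc1/C=C/c1ccccc1Cl`: 50%
- compound 2, `CN(C)CCCCOc1ccccc1/C=C/c1ccccc1F`: 17%

In a functional assay on the whole organism with Mus musculus as the target, at a dose of 50 mg/kg by the oral route (a higher number here means more inhibition at the dose given (going by the name of the read-out), a lower number less inhibition), compound 1 gives 50%. Compound 2 stands lowest of the two numbers; its nearest neighbour is compound 1, and the step of a number 33 percentage points lower from compound 1 to compound 2 (beyond the scatter) lies beyond the scatter.

Compound 3, `CN(C)CCCCOc1ccccc1/C=C/c1cccc(F)c1`, is not yet measured in this assay. It differs from compound 2 in one place: 3-fluorophenyl in place of 2-fluorophenyl on a double-bonded chain carbon bound to a double-bonded chain carbon.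

Going by the values given here, the only measured step, a number 33 percentage points lower from compound 1 to compound 2 (beyond the scatter), exchanges one halogen for another while the position on the ring stays the same; it says nothing about moving the fluoro from the 2-fluorophenyl to the 3-fluorophenyl arrangement. Among the compounds with values here, no measured pair therefore bears on the change from compound 2 to compound 3, and no step beyond the scatter is expected, in either direction, with wide uncertainty. Compound 3 is expected to give about 25% in this assay, estimated between 5% and 50%, which means an expected step of a number 8 percentage points higher from compound 2 to compound 3 (within the scatter).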

Compound 3, a percentage reported as inhibition, in the whole organism at one dose (the size of the read-out at that dose, not a potency): 12.5%
The estimate for compound 3 lay 12.5 percentage points above the measured number; the range from low to high includes it.
By their numbers in this assay, from the lowest: compounds 3 and 2 (each within the scatter of the next); then compound 1.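

Moving the fluoro group in this assay gives a number 4.5 percentage points lower from compound 2 to compound 3 (within the scatter) and so, at this place on a double-bonded chain carbon bound to a double-bonded chain carbon, 3-fluorophenyl and 2-fluorophenyl cannot be told apart. Replacing 2-chlorophenyl with 3-fluorophenyl gives a number 37.5 percentage points lower from compound 1 to compound 3 (beyond the scatter) and so both fluorophenyl groups shown stand clearly under 2-chlorophenyl, which makes the higher number so far specific to the one chloro compound rather than to any halogen on this ring. No measurement on hand offers an explanation for these numbers.

As far as these compounds go, whether the higher number follows chlorine wherever it sits remains open, and 3-chlorophenyl would test this directly against 3-fluorophenyl. Also open, from the compounds shown here alone, are the unsubstituted phenyl group as a baseline for all three halogen compounds and a pyrrolidine in place of the dimethylamino group.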